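Replacing a Tert-Butyl Group with a Pyridine Ring

The source may hold more compounds than are shown below. What is called first, only, known or untested is meant among the compounds shown, and "the series" means these compounds.

Three compounds share one core and differ only in the group carried on an amine nitrogen in a ring. In an assay on membranes from brain for displacement of a labelled ligand from Sigma non-opioid intracellular receptor 1 (Cavia porcellus), read by scintillation counting, with a stated time of 120 min (on this read-out lower numbers stand for stronger inhibition and higher numbers for weaker inhibition), compound 1 `CCN1CCN(CCC(=O)Nc2nc3c(C)cccc3s2)CC1` gives 543 nM, compound 2 `Cc1cccc2sc(NC(=O)CCN3CCN(C(C)(C)C)CC3)nc12` gives 147 nM, and compound 3 `Cc1cccc2sc(NC(=O)CCN3CCN(CCN(C(C)C)C(C)C)CC3)nc12` gives 809 nM. Compound 2 stands lowest of the three, with a step of a 3.7-fold lower number from compound 1 to compound 2 (0.57 log units; beyond the scatter) and a step of a 5.5-fold higher number from compound 2 to compound 3 (0.74 log units; beyond the scatter), so it is the strongest binder among the measured set.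

Compound 4 `Cc1cccc2sc(NC(=O)CCN3CCN(c4ccncc4)CC3)nc12` carries pyridin-4-yl in place of tert-butyl on an amine nitrogen in a ring. The two steps that bear on this position both concern saturated groups: going from ethyl to tert-butyl gave a 3.7-fold lower number from compound 1 to compound 2 (0.57 log units; beyond the scatter), while going from tert-butyl to a longer chain bearing a second amine gave a 5.5-fold higher number from compound 2 to compound 3 (0.74 log units; beyond the scatter). Neither step involves an aromatic ring on this nitrogen, so they only show that this position is sensitive, without saying in which direction an aromatic ring pushes the number.

Given that sensitivity and the absence of a direct precedent, the expectation for compound 4 is a modest rise, a 3.1-fold higher number from compound 2 to compound 4 (0.49 log units; beyond the scatter). Compound 4 is therefore estimated at 450 nM, within a range of 110 nM to 1800 nM.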

Compound 4, inhibition constant: 9600 nM
Estimate against measurement, compound 4: 21-fold (1.33 log units) below, and the stated range ends below it.
By their numbers in this assay, from the lowest: compound 2; then compounds 1 and 3 (each within the scatter of the next); then compound 4.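

In this assay, putting pyridin-4-yl on this amine nitrogen gives a 65-fold higher number from compound 2 to compound 4 (1.81 log units; beyond the scatter) and also an 18-fold higher number from compound 1 to compound 4 (1.25 log units; beyond the scatter) and a 12-fold higher number from compound 3 to compound 4 (1.07 log units; beyond the scatter) so compound 4 is the weakest binder of the four. Among the saturated groups, the largest change was only a 5.5-fold higher number from compound 2 to compound 3 (0.74 log units; beyond the scatter) while each step to the aromatic ring is large, so this position allows a moderate spread across the ethyl, tert-butyl and 2-(diisopropylamino)ethyl groups but shows a much greater loss with pyridin-4-yl. Nothing measured here explains why the pyridin-4-yl group has such a large effect.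

Going by these compounds alone, with only one aromatic group at this position, it remains open whether the loss goes with the ring nitrogen of the pyridine, with its location in the ring, or with any aromatic ring on this nitrogen, and a phenyl or pyridin-3-yl group here would help separate these possibilities. From the compounds shown here alone, it is also open whether a saturated six-membered ring such as cyclohexyl would stay close to compound 2 at 147 nM or move toward compound 4 at 9600 nM in the same assay.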